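The source may report more compounds than this note shows. Statements on the series, on what has been measured and on what is new or still open speak of the compounds shown alone.

In a functional assay on MCF7 cells (Homo sapiens) for cytotoxicity, read by MTT assay, with a stated time of 96 h (on this read-out higher numbers stand for weaker inhibition and lower numbers for stronger inhibition), compound 1 `COc1cc(C(=O)c2cn(-c3ccccc3)cc2-c2ccc(N)cc2)cc(OC)c1OC` gives 9 nM and compound 2 `COc1cc(C(=O)c2cn(-c3ccccc3)cc2-c2ccccc2[N+](=O)[O-])cc(OC)c1OC` gives 49 nM, the higher of the two numbers. Compound 3 `COc1cc(C(=O)c2cn(-c3cccc(C)c3)cc2-c2ccccc2[N+](=O)[O-])cc(OC)c1OC` differs from compound 2 by methyl in place of hydrogen on an aromatic carbon, phenyl to 3-methylphenyl. Among the compounds with values here, the only measured step, a 5.4-fold higher number from compound 1 to compound 2 (0.74 log units; beyond the scatter), lies at another place in the structure, so its size does not carry over, and no measured step covers this methyl. From the compounds shown here alone, no step beyond the scatter is therefore expected in this assay, and the direction remains open. The estimated shift is a 1.2-fold higher number from compound 2 to compound 3 (0.09 log units; within the scatter). For compound 3 the expected value is 60 nM, with an estimated range from 20 nM to 180 nM.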

Compound 3, half-maximal inhibitory concentration: 220 nM
For compound 3 the middle estimate is 3.7-fold (0.56 log units) below the measured one, outside the stated range (above it).
By their numbers in this assay, from the lowest: compound 1; then compound 2; then compound 3.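

The change from phenyl to 3-methylphenyl gives a 4.5-fold higher number from compound 2 to compound 3 (0.65 log units; beyond the scatter) in this assay, so a single added methyl at this aromatic carbon is enough to move the number beyond the scatter, towards weaker inhibition. The earlier step lay at another place in the structure and said nothing about this ring. Nothing available here bears on the cause of this step.

From the compounds shown here alone, whether a larger alkyl chain, a methoxy group or an amine at this carbon would move the number the same way stays open. So does whether the methyl has the same effect with the 4-aminophenyl group of compound 1 in place of 2-nitrophenyl.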